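This account rests on a few compounds, and the source may have more. Where it says the series, first, only, none or still open, it means among the compounds named here.

Compound 1, `Cc1ccc(Cn2cc(COc3ccc4c(=O)ccoc4c3)nn2)cc1`, was tested in a functional assay on HeLa cells (Homo sapiens) for cytotoxicity, read by MTT assay, with a stated time of 48 h (a lower number here means a stronger inhibitor, a higher number a weaker inhibitor), where compound 1 gives > 100000 nM, a value that is a limit of the assay rather than a number. Two close relatives were run in the same test. Compound 2, `O=c1ccoc2cc(OCc3cn(Cc4ccccc4Cl)nn3)ccc12`, gives > 100000 nM in this assay, again a limit. Compound 3, `N#Cc1ccc(Cn2cc(COc3ccc4c(=O)ccoc4c3)nn2)cc1`, gives > 100000 nM in this assay, also a limit. All three thus share (the limit of > 100000 nM in this assay, at which 3 of the 3 values shown sit), so none of the changes among them can be read in size or direction: the steps are a step that the two limits leave unreadable from compound 1 to compound 2, a step that the two limits leave unreadable from compound 1 to compound 3 and a step that the two limits leave unreadable from compound 2 to compound 3.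

Compound 4, `O=c1ccoc2cc(OCc3cn(Cc4ccccc4Br)nn3)ccc12`, differs from compound 1 in one place: 2-bromophenyl in place of 4-methylphenyl on a saturated chain carbon bound to an aromatic nitrogen. The measured step that bears most closely on this change is a step that the two limits leave unreadable from compound 1 to compound 2, in which another halogen-bearing phenyl, the 2-chlorophenyl, took the place of the 4-methylphenyl, and that step could not be read. With every measured value sitting at the limit, no step beyond the scatter is expected here, and compound 4 is expected to sit at the limit as well. Compound 4 is therefore estimated at 200000 nM, within a range from 50000 nM to 800000 nM. This amounts to an expected step that the limit leaves unreadable from compound 1 to compound 4.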

Compound 4, half-maximal inhibitory concentration: 14500 nM
Compound 4: the middle estimate sits 14-fold (1.14 log units) above what was measured; the measured number lies below the stated range.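

In this assay, a change on a saturated chain carbon bound to an aromatic nitrogen can move the read-out, something the earlier compounds could not show, since the steps among them cannot be read: the limit of > 100000 nM in this assay, at which 3 of the 4 values shown sit.

With 2-bromophenyl at this place, the readable steps are an at least 6.8-fold lower number from compound 1 to compound 4 (0.83 log units; beyond the scatter) and an at least 6.8-fold lower number from compound 3 to compound 4 (0.83 log units; beyond the scatter), and each size is only a minimum, its starting value being a limit. The closest comparison is the exchange of a single atom, bromo in place of chloro on an aromatic carbon, which gives an at least 6.8-fold lower number from compound 2 to compound 4 (0.83 log units; beyond the scatter), so among these compounds a halogen on the phenyl ring does not by itself bring a measurable value, as compound 2 with its chloro shows.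

The compounds shown leave open why bromo and chloro part ways here, and whether an iodo group in the same place would carry the number further down. As far as these compounds go, the true size of each step also stays open, as does what an amine or a carboxylic acid on this phenyl ring would do to the read-out.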